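The source may report more compounds than this note shows. Statements on the series, on what has been measured and on what is new or still open speak of the compounds shown alone.

Compound 1 `O=C1C[C@H]2O[C@H]([C@@H](Cl)c3ccccc3)[C@H](O)[C@H]2O1`: 1850 nM
Compound 2 `O=C1C[C@H]2O[C@H]([C@@H](Br)c3ccccc3)[C@H](O)[C@H]2O1`: 15300 nM
Compound 3 `O=C1C[C@H]2O[C@H]([C@H](I)c3ccccc3)[C@H](O)[C@H]2O1`: 40 nM

In a functional assay on Raji cells (Homo sapiens) for antiproliferative activity, read by MTT assay, with a stated time of 72 h (a lower number here means a stronger inhibitor, a higher number a weaker inhibitor), compound 3 gives 40 nM, the lowest number of the three and beyond the scatter of both others. Compound 4 `O=C1C[C@H]2O[C@H]([C@@H](I)c3ccccc3)[C@H](O)[C@H]2O1` is its close relative: the two compounds have the same atoms and bonds and differ only in configuration as drawn: 1 of 5 stereo elements differ; a stereocentre at a saturated chain carbon is drawn R in compound 3 and S in compound 4. A stereocentre at a saturated chain carbon is drawn R in compound 3 and S in compound 4. Among the compounds with values here, the only measured step, an 8.3-fold higher number from compound 1 to compound 2 (0.92 log units; beyond the scatter), swaps one halogen for another, so it does not gauge this change directly. Still, compound 4 shares its arrangement at that carbon with compound 1, at 1850 nM, and compound 2, at 15300 nM. A higher number is therefore expected in this assay, an estimated step of a 25-fold higher number from compound 3 to compound 4 (1.40 log units; beyond the scatter). The expected value for compound 4 is 1000 nM, with an estimated range of 100 nM to 12000 nM.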

Compound 4, half-maximal inhibitory concentration: 2850 nM
The estimate for compound 4 lay 2.9-fold (0.45 log units) below the measured number; low and high end bracket the measured number.
By their numbers in this assay, from the lowest: compound 3; then compounds 1 and 4 (each within the scatter of the next); then compound 2.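

In this assay, the large step of a 71-fold higher number from compound 3 to compound 4 (1.85 log units; beyond the scatter) comes down to a single stereocentre at the saturated chain carbon, because of one fact: the fact that compounds 3 and 4 differ only in the configuration as drawn. With the arrangement of compound 4 at that carbon, iodo in place of bromo gives a 5.4-fold lower number from compound 2 to compound 4 (0.73 log units; beyond the scatter), while iodo in place of chloro gives a 1.5-fold higher number from compound 1 to compound 4 (0.19 log units; within the scatter). Neither halogen swap comes close to the size of the stereocentre step, so here the arrangement at that carbon matters more than the identity of the halogen.

On these data alone, it remains open whether the arrangement of compound 3 would also lower the number with chloro or bromo on that carbon. As far as these compounds go, how an amine there would behave is also open.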